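Replacing methoxycarbonyl with bromo in the series

This account rests on a few compounds, and the source may have more. Where it says the series, first, only, none or still open, it means among the compounds named here.

In an ADME assay on a cell-free system (plasma, Homo sapiens) for metabolic stability, read by HPLC (on this read-out higher numbers stand for a longer-lived compound and lower numbers for a shorter-lived compound), compound 1 `CCOC(=O)c1ccc(/N=N/N(C)C(=O)CCCCc2ccc(O)cc2)cc1` gives 26.3 h, compound 2 `CC(=O)c1ccc(/N=N/N(C)C(=O)CCCCc2ccc(O)cc2)cc1` gives 32.7 h and compound 3 `COC(=O)c1ccc(/N=N/N(C)C(=O)CCCCc2ccc(O)cc2)cc1` gives 17.5 h. The two steps reaching the last of these are a 1.5-fold lower number from compound 1 to compound 3 (0.18 log units; within the scatter) and a 1.9-fold lower number from compound 2 to compound 3 (0.27 log units; within the scatter), so the numbers do not separate it from the other two.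

Compound 4 `CN(/N=N/c1ccc(Br)cc1)C(=O)CCCCc1ccc(O)cc1` changes the same substituent: bromo in place of methoxycarbonyl on an aromatic carbon. The measured changes at this substituent alter only the group on its carbonyl carbon. They are the two steps above and a 1.2-fold higher number from compound 1 to compound 2 (0.09 log units; within the scatter), and none goes beyond the scatter. For the measured compounds named here, no measured step replaces the whole group, so the present change is untested and the range must stay wide. With that limitation, no step beyond the scatter is expected in this assay, in either direction. The expected change is a 1.1-fold higher number from compound 3 to compound 4 (0.06 log units; within the scatter). The estimated half-life of compound 4 is 20 h, with an expected range of 8 h to 45 h.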

Compound 4, half-life: 162 h
Beside the measured number, compound 4's estimate is 8.1-fold (0.91 log units) below it, outside the stated range (above it).
By their numbers in this assay, from the lowest: compounds 3, 1 and 2 (each within the scatter of the next); then compound 4.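

In this assay, replacing the whole carbonyl-bearing group on this aromatic carbon with bromo gives steps beyond the scatter from all three earlier compounds: (a 9.3-fold higher number from compound 3 to compound 4 (0.97 log units; beyond the scatter)), (a 6.2-fold higher number from compound 1 to compound 4 (0.79 log units; beyond the scatter)) and (a 5.0-fold higher number from compound 2 to compound 4 (0.69 log units; beyond the scatter)). The earlier changes altered only the group on the carbonyl carbon and stayed within the scatter, so this position shows a clear response only once that whole group is exchanged, and compound 4 stands apart from compound 1, compound 2 and compound 3. Nothing available bears on why the number rises with this change.

The compounds shown leave open whether the higher number belongs to bromo itself or to the absence of the carbonyl group, which chloro, a nitrile or plain hydrogen on this carbon would help separate. From the compounds shown here alone, how a carboxylic acid or an amine at the same place would read also remains open.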